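Swapping the amide amine on compound 3

The source may report more compounds than this note shows. Statements on the series, on what has been measured and on what is new or still open speak of the compounds shown alone.

compound 1 `COc1ccc(-c2oc3c(OC)c(OC)cc(OCCCC(=O)N4CCN(C)CC4)c3c(=O)c2O)cc1` gives > 40000 nM as a limit
compound 2 `COc1ccc(-c2oc3c(OC)c(OC)cc(OCCCCC(=O)NCc4ccccn4)c3c(=O)c2O)cc1` gives > 40000 nM as a limit
compound 3 `CCCCCN(C)C(=O)CCCCCOc1cc(OC)c(OC)c2oc(-c3ccc(OC)cc3)c(O)c(=O)c12` gives 19400 nM as a true number

Going by the values given here, in a functional assay on DLD-1 cells (Homo sapiens) for antiproliferative activity, read by sulforhodamine B assay, with a stated time of 48 h (a lower number here means a stronger inhibitor, a higher number a weaker inhibitor), compound 3 at 19400 nM is the only compound with a true number. The other two sit at limits. The move to compound 4 `COc1ccc(-c2oc3c(OC)c(OC)cc(OCCCCCC(=O)N4CCN(C)CC4)c3c(=O)c2O)cc1` is 4-methylpiperazin-1-yl in place of methyl(pentyl)amino on a carbonyl carbon and puts 4-methylpiperazin-1-yl in place of methyl(pentyl)amino on a carbonyl carbon.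

The closest guide is an at least 2.0-fold lower number from compound 1 to compound 3 (0.31 log units; beyond the scatter) and it leads away from this same 4-methylpiperazin-1-yl group. It also alters the chain, so it is only a partial match. A second, looser guide is an at least 2.0-fold lower number from compound 2 to compound 3 (0.31 log units; beyond the scatter) and it starts from a different amide. Together they lead to the expectation of a higher number, meaning a weaker compound. Compound 4 could also end at the limit of > 40000 nM in this assay, at which 2 of the 3 values shown sit, and give no number.

The expected change is a 2.0-fold higher number from compound 3 to compound 4 (0.29 log units; within the scatter) and it remains an estimate. For compound 4 the estimated value is 38000 nM (expected range 20000 nM to 70000 nM).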

Compound 4, half-maximal inhibitory concentration: 13700 nM
Compound 4: middle estimate off by 2.8-fold (0.44 log units), on the high side, and the stated range ends above it.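

In this assay, exchanging the amine on the carbonyl carbon gives a 1.4-fold lower number from compound 3 to compound 4 (0.15 log units; within the scatter), so methyl(pentyl)amino and 4-methylpiperazin-1-yl cannot be told apart on this chain. With the 4-methylpiperazin-1-yl amide held fixed, changing only the chain gives an at least 2.9-fold lower number from compound 1 to compound 4 (0.46 log units; beyond the scatter), while replacing the ((pyridin-2-yl)methyl)carbamoyl group gives an at least 2.9-fold lower number from compound 2 to compound 4 (0.46 log units; beyond the scatter). Both of those steps start from a limit rather than a true number, as compound 1 and compound 2 give no number: the limit of > 40000 nM in this assay, at which 2 of the 4 values shown sit.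

On these data alone, the full size of those two steps therefore stays open. As far as these compounds go, it is also open whether a longer chain would lower the number further, and whether a morpholine amide or a free carboxylic acid at the carbonyl carbon would match these two amides.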